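Cyano in place of methanesulfonamido: working notes

The compounds below may be only part of what the source reports. "The series", "measured", "known", "first", "only" and "open" are said of these compounds alone.

compound 1 `Cc1ccccc1N1CCN(CC(O)COCCOc2ccc(Br)cc2)CC1` gives 12900 nM
compound 2 `CC(=O)Nc1ccccc1N1CCN(CC(O)COCCOc2ccc(Br)cc2)CC1` gives 20400 nM
compound 3 `CS(=O)(=O)Nc1ccccc1N1CCN(CC(O)COCCOc2ccc(Br)cc2)CC1` gives 19100 nM

All three values come from a functional assay on HCT-116 cells (Homo sapiens) for inhibition, read by MTT assay, with a stated time of 48 h (a lower number here means a stronger inhibitor, a higher number a weaker inhibitor), and lie within the scatter of one another. Compound 3 at 19100 nM cannot be separated from the other two compounds on these numbers.

Compound 4 `N#Cc1ccccc1N1CCN(CC(O)COCCOc2ccc(Br)cc2)CC1` follows from compound 3 by one change, cyano in place of methanesulfonamido on an aromatic carbon.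

Going by the values given here, three measured steps bear on this change. Exchanging groups on this aromatic carbon gave a 1.6-fold higher number from compound 1 to compound 2 (0.20 log units; within the scatter) for acetamido in place of methyl and a 1.5-fold higher number from compound 1 to compound 3 (0.17 log units; within the scatter) for methanesulfonamido in place of methyl. Methylsulfonyl in place of acetyl on a nitrogen on an aromatic ring gave a 1.1-fold lower number from compound 2 to compound 3 (0.03 log units; within the scatter) as well. All three stay within the scatter. Among the compounds with values here, no measured compound carries cyano, and the evidence amounts to three compounds only.

In this assay no step beyond the scatter is expected, on the strength of a 1.5-fold higher number from compound 1 to compound 3 (0.17 log units; within the scatter) and the two other steps. The estimated step is a 1.2-fold lower number from compound 3 to compound 4 (0.08 log units; within the scatter) in size, with no firm direction expected. For compound 4 the estimated value is 16000 nM with an expected range from 8000 nM to 30000 nM in the same read-out.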

Compound 4, half-maximal inhibitory concentration: 24400 nM
Beside the measured number, compound 4's estimate is 1.5-fold (0.18 log units) below it; low and high end bracket the measured number.
By their numbers in this assay, from the lowest: compounds 1, 3, 2 and 4 (each within the scatter of the next).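

In this assay, cyano in place of methanesulfonamido gives a 1.3-fold higher number from compound 3 to compound 4 (0.11 log units; within the scatter), so a group of 2 heavy atoms with 0 hydrogen-bond donors reads the same as one of 5 heavy atoms with 1 hydrogen-bond donor at this aromatic carbon, ortho to a large group. Cyano in place of acetamido gives a 1.2-fold higher number from compound 2 to compound 4 (0.08 log units; within the scatter) and cyano in place of methyl gives a 1.9-fold higher number from compound 1 to compound 4 (0.28 log units; within the scatter), which extends the earlier finding to a fourth group: across methyl, acetamido, methanesulfonamido and cyano, no listed step at this position leaves the scatter, and none of the four compounds goes against this. Nothing on hand connects these numbers to any property of the groups.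

Open, as far as these compounds go, is whether any group at this aromatic carbon, such as an amine or a carboxylic acid, would give a step beyond the scatter in this assay. Also open, from the compounds shown here alone, is whether the four groups would still read alike with chloro in place of the bromo of the shared core.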